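Iodo for acetyl on the urea aryl ring

The source may hold more compounds than are shown below. What is called first, only, known or untested is meant among the compounds shown, and "the series" means these compounds.

Measured compounds:
- compound 1, `C[C@H](NC(=O)Nc1ccccc1C(C)(C)C)c1ccccc1`, 99%
- compound 2, `CC(=O)c1ccccc1NC(=O)N[C@H](C)c1ccccc1`, 95%
- compound 3, `CC(=O)c1ccccc1NC(=O)N[C@@H](C)c1ccccc1`, 97%

In an ADME assay on the whole organism with Oryza sativa as the target, tested at 1 uM (a higher number here means a weaker effect of the compound at the concentration tested, a lower number a stronger effect), compound 3 gives 97%, the second highest of the three numbers shown, with compound 1 nearest and compound 2 furthest, both within the scatter. The two measured steps are small: a number 2 percentage points lower from compound 1 to compound 3 (within the scatter), and a number 2 percentage points higher from compound 2 to compound 3 (within the scatter), the latter resting only on (the fact that compounds 2 and 3 differ only in the configuration as drawn).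

Compound 4, `C[C@H](NC(=O)Nc1ccccc1I)c1ccccc1`, has not yet been measured in this assay. It differs from compound 3 in one place: iodo in place of acetyl on an aromatic carbon. Among the compounds with values here, the step from compound 1 to compound 3 is the only one that changes a group at that same aromatic carbon, and it stayed within the scatter; the step from compound 2 to compound 3 does not bear on the substituent at all. Within the data shown here, no measured step involves iodo. On this basis no step beyond the scatter is expected for compound 4, so that no change at the digits printed from compound 3 to compound 4 (within the scatter) is expected to be small. Compound 4 is therefore estimated at 97%, with a range from 86% to 100%.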

Compound 4, a percentage reported as activity, at one concentration (the size of the read-out at that concentration, not a potency): 100%
Estimate against measurement, compound 4: 3 percentage points below; low and high end bracket the measured number.
By their numbers in this assay, from the lowest: compounds 2, 3, 1 and 4 (each within the scatter of the next).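

In this assay this aromatic carbon now carries a third group, and iodo in place of acetyl gives a number 3 percentage points higher from compound 3 to compound 4 (within the scatter) while iodo in place of tert-butyl gives a number 1 percentage points higher from compound 1 to compound 4 (within the scatter) as well. Compounds 1, 3 and 4 therefore lie within the scatter of one another, so at this place the read-out does not separate acetyl, tert-butyl and iodo, even though iodo brings a single heavy atom and removes the hydrogen-bond acceptor of acetyl. No available evidence bears on this result.

As far as these compounds go, whether an amine or a carboxylic acid on this aromatic carbon would move the number beyond the scatter remains open. From the compounds shown here alone, the opposite configuration at the saturated chain carbon appears only with acetyl, so its effect with iodo or tert-butyl is also open.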